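Nitro to Nitrile Exchange in a Cytotoxicity Series

This account rests on a few compounds, and the source may have more. Where it says the series, first, only, none or still open, it means among the compounds named here.

Compound 1 `COc1ccc(/C=C/C(=O)/C=C(O)/C=C/c2ccc(OC(C)(C)C(=O)Nc3ccc([N+](=O)[O-])c(C(F)(F)F)c3)c(OC)c2)cc1OC` gives in a functional assay on LNCaP cells (Homo sapiens) for cytotoxicity, read by sulforhodamine B assay, with a stated time of 72 h (on this read-out higher numbers stand for weaker inhibition and lower numbers for stronger inhibition), the limit > 100000 nM.
Compound 2 `COc1ccc(/C=C/C(=O)/C=C(O)/C=C/c2ccc(OC(C)(C)C(=O)Nc3ccc(C#N)c(C(F)(F)F)c3)c(OC)c2)cc1OC` gives in this assay the limit > 100000 nM.
Compound 3 `COc1ccc(/C=C/C(=O)/C=C(O)/C=C/c2ccc(OCC(C)(O)C(=O)Nc3ccc([N+](=O)[O-])c(C(F)(F)F)c3)c(OC)c2)cc1OC` gives in this assay 41800 nM.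

Compound 1 and compound 2 share one core and differ only at the far end of the amide-bearing side chain: cyano in place of nitro on an aromatic carbon. The value of compound 1 is a limit of the assay and not a number. The value of compound 2 is likewise a limit. For that reason the step that the two limits leave unreadable from compound 1 to compound 2 cannot be read in size; the reason is the limit of > 100000 nM in this assay, at which 2 of the 3 values shown sit.

Compound 3 carries a different side chain, and the difference between the two cores is not broken down here. Compound 3 is the only one of the three with a measured number in this assay. Compound 4 `COc1ccc(/C=C/C(=O)/C=C(O)/C=C/c2ccc(OCC(C)(O)C(=O)Nc3ccc(C#N)c(C(F)(F)F)c3)c(OC)c2)cc1OC` has not yet been measured; it stands to compound 3 as compound 2 stands to compound 1, the same change at the same place: cyano in place of nitro on an aromatic carbon.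

Since the measured instance of this change is unreadable, the expectation for compound 4 rests mainly on the value of compound 3 and on the usual scatter, and a step near a 1.4-fold higher number from compound 3 to compound 4 (0.16 log units; within the scatter) is estimated. The estimated value of compound 4 in this assay is 60000 nM, with a range from 20000 nM to 150000 nM, and a real chance that only a limit is returned.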

Compound 4, half-maximal inhibitory concentration: 73000 nM
Beside the measured number, compound 4's estimate is 1.2-fold (0.09 log units) below it, within the range that was stated.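

In this assay the exchange of nitro for cyano on the core of compound 3 gives a 1.7-fold higher number from compound 3 to compound 4 (0.24 log units; within the scatter) and so, on this core, the two compounds cannot be told apart on this read-out. This is a single readable pair, so it shows that the exchange left no measurable mark in this one setting, not that nitro and cyano can be swapped freely throughout the series. Whether the result carries over from one core to the other cannot be judged, because the matching step from compound 1 to compound 2 cannot be read in size, as the values of both compounds are limits and not numbers: the limit of > 100000 nM in this assay, at which 2 of the 4 values shown sit.

The compounds shown leave open how other groups would read at the same aromatic carbon, which sits ortho to the trifluoromethyl group, for example an amine or a carboxylic acid in place of the nitro or cyano group. They also leave open whether a longer chain between the aromatic ring and the amide would bring the exchange into a range where a second step could be read on the core of compound 1.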